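Ring size on the aromatic oxygen of the shared core

This account rests on a few compounds, and the source may have more. Where it says the series, first, only, none or still open, it means among the compounds named here.

The shared core carries an oxygen on an aromatic ring, and the group on that oxygen is varied. Compound 1 `Nc1ccc2cccc(OC3CCCCC3)c2n1` gives 361 nM in an assay on cells with melanin-concentrating hormone receptor 1 (Homo sapiens) as the target, read by radioligand binding (on this read-out higher numbers stand for weaker inhibition and lower numbers for stronger inhibition), and holds the highest of the two numbers measured; the nearest is compound 2 `Nc1ccc2cccc(OCC3CCCC3)c2n1`, which gives 53 nM in this assay, a change of a 6.8-fold lower number from compound 1 to compound 2 (0.83 log units; beyond the scatter). Compound 3 `Nc1ccc2cccc(OCC3CC3)c2n1` gives > 2000 nM in this assay, which is a limit of the assay rather than a number (the limit of > 2000 nM in this assay, at which 1 of the 3 values shown sits). From compound 1 the limit means an at least 5.5-fold higher number from compound 1 to compound 3 (0.74 log units; beyond the scatter), and between compound 2 and compound 3 the gap is an at least 37-fold higher number from compound 2 to compound 3 (1.57 log units; beyond the scatter).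

Compound 4 `Nc1ccc2cccc(OCC3CCC3)c2n1` differs from compound 1 by cyclobutylmethyl in place of cyclohexyl on an oxygen on an aromatic ring. Both steps from compound 1 bear on this: cyclopentylmethyl lowered the number, cyclopropylmethyl pushed it past the limit, and cyclobutylmethyl sits between those two ring sizes. Going by the values given here, no measured step places a four-membered ring, so the outcome is read as lying between the two neighbours. For compound 4 the step of a 1.4-fold higher number from compound 1 to compound 4 (0.14 log units; within the scatter) is expected to be small, within the scatter or a slight rise. Compound 4 is therefore estimated at 500 nM, within 150 nM to 2000 nM.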

Compound 4, half-maximal inhibitory concentration: 432 nM
Compound 4: middle estimate off by 1.2-fold (0.06 log units), on the high side, and the stated range covers the measured number.
By their numbers in this assay, from the lowest: compound 2; then compounds 1 and 4 (each within the scatter of the next). At a limit, above all of these: compound 3.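

In this assay, cyclobutylmethyl on the oxygen on an aromatic ring cannot be told apart from cyclohexyl, with a 1.2-fold higher number from compound 1 to compound 4 (0.08 log units; within the scatter), yet one ring size separates it from the best group shown, with an 8.2-fold higher number from compound 2 to compound 4 (0.91 log units; beyond the scatter), so the benefit of cyclopentylmethyl does not extend to the four-membered ring. Going down one more ring size costs further, with an at least 4.6-fold lower number from compound 3 to compound 4 (0.66 log units; beyond the scatter), so among the three methyl-linked rings the number falls as the ring grows, and none of these three goes against that order. That last step rests on compound 3, whose value is a limit of the assay and not a number: the limit of > 2000 nM in this assay, at which 1 of the 4 values shown sits.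

The compounds shown leave open whether the order continues with cyclohexylmethyl or reverses once the ring is larger than cyclopentyl, and how cyclopentyl set directly on the oxygen compares with cyclopentylmethyl. Also open, on these data alone, is whether a longer chain in place of the methyl link, or a ring carrying an amine, would keep the number of compound 2, 53 nM.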